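Four Compounds and One Repeated Change

The source may hold more compounds than are shown below. What is called first, only, known or untested is meant among the compounds shown, and "the series" means these compounds.

Of the compounds shown here, three have so far been measured in a physicochemical assay for metabolic stability, read by LC-MS, in simulated gastric fluid, with a stated time of 15 min, tested at 50 uM; a higher number here means that more of the compound is left, a lower number that less of the compound is left. Compound 1 `CCc1ccccc1OC(=O)c1coc(-c2ccccc2)n1` gives 2.1%. Compound 2 `O=C(Oc1ccccc1C(F)(F)F)c1coc(-c2ccccc2)n1` gives 1.2% in this assay, and compound 3 `O=C(OCc1ccccc1C(F)(F)F)c1coc(-c2ccccc2)n1` gives 0.8%. Compound 4 `CCc1ccccc1COC(=O)c1coc(-c2ccccc2)n1` has not yet been measured in this assay.

The structural change from compound 2 to compound 1 is ethyl in place of trifluoromethyl on an aromatic carbon. This change produced a number 0.9 percentage points higher from compound 2 to compound 1 (within the scatter), a step that stays within the usual scatter of such measurements. Compound 3 carries a different core from compound 2, and the difference between the two cores is not broken down here.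

Compound 4 arises from compound 3 by the same change: ethyl in place of trifluoromethyl on an aromatic carbon. This change appears twice among the compounds shown. Because the earlier occurrence gave a number 0.9 percentage points higher from compound 2 to compound 1 (within the scatter), a step of similar size is expected here, namely a number 0.9 percentage points higher from compound 3 to compound 4 (within the scatter). On this basis compound 4 is estimated to give about 1.7% in this assay, most likely between 0% and 6%.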

Compound 4, percent of the compound remaining: 3.2%
Estimate against measurement, compound 4: 1.5 percentage points below; the measured number falls inside the stated range.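

Swapping trifluoromethyl for ethyl on an aromatic carbon was tried on two cores, and in this assay it gives a number 2.4 percentage points higher from compound 3 to compound 4 (within the scatter) and, on the other core, a number 0.9 percentage points higher from compound 2 to compound 1 (within the scatter) in the same assay. This shows that the change, carried from one core to the other, did not move the read-out beyond what repeated measurements alone can produce on either core, so neither step can be taken as a real effect, and the two steps cannot be used to say that the cores respond alike or differently. No measurement is available here that would explain these numbers.

Going by these compounds, what an amine, a carboxylic acid or a chain longer than ethyl would do at this same place on the aromatic ring remains open. The compounds shown also leave open whether this change would keep to the same small steps on a third core, since only two cores carry it here.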